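The source may hold more compounds than are shown below. What is called first, only, known or untested is meant among the compounds shown, and "the series" means these compounds.

Working notes on the series, read in an in vitro ADME assay on microsomes from liver (Homo sapiens) for metabolic stability; a higher number here means faster removal of the compound, a lower number slower removal. Compound 1 (`COc1ccc(Sc2c(C)n(CC(=O)O)c3ccc(C)cc23)cc1`) reports < 3 mL.min-1.g-1, which is a limit of the assay and not a number. Compound 3 (`Cc1c(Sc2ccc(Cl)cc2)c2c(-c3nccs3)cccc2n1CC(=O)O`) gives 43 mL.min-1.g-1, the higher of the two actual numbers and beyond the scatter of compound 2 (`Cc1c(Sc2ccc(Cl)cc2)c2c(C#N)c(Cl)ccc2n1CC(=O)O`), which gives 4 mL.min-1.g-1. Compound 4 (`CNC(=O)c1cccc2c1c(Sc1ccc(Cl)cc1)c(C)n2CC(=O)O`) has methylcarbamoyl in place of 1,3-thiazol-2-yl on an aromatic carbon. Within the data shown here, no measured pair isolates this change. Only compound 3 carries 1,3-thiazol-2-yl, and compound 2 without it stands at 4 mL.min-1.g-1, so a fall beyond the scatter is expected. The expected step is a 4.3-fold lower number from compound 3 to compound 4 (0.63 log units; beyond the scatter). For compound 4 the estimate is 10 mL.min-1.g-1, with an expected range of 4 mL.min-1.g-1 to 25 mL.min-1.g-1.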

Compound 4, intrinsic clearance in microsomes: < 3 mL.min-1.g-1
Compound 4: no number, only a limit (the forecaster's own chance of this, stated with the estimate: 15%); at least 3.3-fold (0.52 log units) between middle value and limit.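

Methylcarbamoyl in place of 1,3-thiazol-2-yl on an aromatic carbon gives an at least 14-fold lower number from compound 3 to compound 4 (1.15 log units; beyond the scatter), the first direct reading of a change at this position in this assay. Compound 4 reports < 3 mL.min-1.g-1, which is a limit of the assay and not a number. The step is therefore a bound and not an exact size, because compound 4 sits at that limit: the limit of < 3 mL.min-1.g-1 in this assay, at which 2 of the 4 values shown sit.

How far compound 4 lies past its limit cannot be read. Also open, from the compounds shown here alone, is whether an amine or a longer chain in place of methylcarbamoyl on this aromatic carbon would read like compound 4 or like compound 3.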